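The source may hold more compounds than are shown below. What is called first, only, known or untested is meant among the compounds shown, and "the series" means these compounds.

Within the data shown here, compound 2 `NC/C=C(/F)COc1ccc(C(F)(F)F)cc1` gives 40 nM in an assay on isolated protein for inhibition of Amine oxidase [copper-containing] 3 (Homo sapiens), read by Amplex Red (on this read-out lower numbers stand for stronger inhibition and higher numbers for weaker inhibition), the lower of the two numbers measured so far, and compound 1 `COc1ccc(OC/C(F)=C\CN)cc1` gives 160 nM. Among the measured compounds shown here, the single measured step, a 4.0-fold lower number from compound 1 to compound 2 (0.60 log units; beyond the scatter), shows that exchanging the group on this aromatic carbon can shift the number well beyond the usual scatter. Compound 3 `NC/C=C(/F)COc1ccc(C(N)=O)cc1` carries a different exchange at that carbon: carbamoyl in place of trifluoromethyl on an aromatic carbon. For the measured compounds named here, no measured step involves carbamoyl, so the direction rests on little. The step is expected to be a 2.5-fold higher number from compound 2 to compound 3 (0.40 log units; beyond the scatter). Compound 3 is therefore estimated at 100 nM, within a range from 30 nM to 400 nM.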

Compound 3, half-maximal inhibitory concentration: 1070 nM
Compound 3: middle estimate off by 11-fold (1.03 log units), on the low side; the whole stated range lies below it.
By their numbers in this assay, from the lowest: compound 2; then compound 1; then compound 3.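

In this assay this aromatic carbon proves far less forgiving than the first step suggested: carbamoyl in place of trifluoromethyl gives a 27-fold higher number from compound 2 to compound 3 (1.43 log units; beyond the scatter) here. Carbamoyl in place of methoxy also raises the number, with a 6.7-fold higher number from compound 1 to compound 3 (0.83 log units; beyond the scatter) as the step, so carbamoyl gives the weakest inhibition of the three groups. No evidence given here explains this loss.

From the compounds shown here alone, it remains open whether a carboxylic acid or an amine at this carbon would behave like carbamoyl, and whether a nitrile or a chlorine atom would keep the number near that of trifluoromethyl.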